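The source may report more compounds than this note shows. Statements on the series, on what has been measured and on what is new or still open speak of the compounds shown alone.

Compound 1 `ClCc1cccc(Cn2cnc3ncnc(Cl)c32)c1` and compound 2 `ClCc1cccc(Cn2cnc3c(Cl)ncnc32)c1` are built from the same atoms joined differently; the difference between the two cores is not broken down here. Compound 3 `ClCc1cccc(Cn2cnc3c(Cl)nc(Cl)nc32)c1` arises from compound 2 through (chloro in place of hydrogen on an aromatic carbon). Compound 4 `ClCc1cccc(Cn2cnc3nc(Cl)nc(Cl)c32)c1` arises from compound 1 through (chloro in place of hydrogen on an aromatic carbon), the same change at a place described in the same words.

In a functional assay on SNB-75 cells (Homo sapiens) for cytotoxicity, read by sulforhodamine B assay, with a stated time of 48 h (a lower number here means that less compound is tolerated, a higher number that more compound is tolerated), compound 1 gives 7940 nM. In this assay compound 2 gives 10000 nM, and compound 3 gives 7410 nM. The measured step of a 1.3-fold lower number from compound 2 to compound 3 (0.13 log units; within the scatter) shows that adding the chloro group left the read-out essentially unchanged.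

Among the compounds with values here, because the only precedent is a 1.3-fold lower number from compound 2 to compound 3 (0.13 log units; within the scatter), compound 4 is expected to show a similarly small step, a 1.2-fold lower number from compound 1 to compound 4 (0.09 log units; within the scatter). Compound 4 is therefore estimated at 6500 nM, plausibly between 3000 nM and 14000 nM.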

Compound 4, concentration lethal to 50% of the cells: 4780 nM
Estimate against measurement, compound 4: 1.4-fold (0.13 log units) above; measured number inside the range.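

In this assay, placing the chloro group on the core of compound 1 gives a 1.7-fold lower number from compound 1 to compound 4 (0.22 log units; within the scatter), so the read-out again stays essentially unchanged. Set beside the earlier step, the change behaves alike on the two cores: the same change on two cores in this assay, a 1.3-fold lower number (0.13 log units; within the scatter) from compound 2 to compound 3 and a 1.7-fold lower number (0.22 log units; within the scatter) from compound 1 to compound 4, 1.2-fold (0.09 log units) apart, within the scatter of two such steps. This shows that the change carries across these two closely related cores without a step beyond the scatter, but it does not show that it would carry to any other core, and steps this small reveal no clear effect to transfer.

The compounds shown hold only hydrogen or chloro on the aromatic carbon between two ring nitrogen atoms. As far as these compounds go, whether an amine or a methoxy group at that place would shift the read-out remains open.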